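Swapping the Substituent on the Ring Nitrogen

The source may hold more compounds than are shown below. What is called first, only, known or untested is meant among the compounds shown, and "the series" means these compounds.

In a functional assay on HCC1806 cells (Homo sapiens) for inhibition, read by sulforhodamine B assay, tested at 10 uM (a higher number here means more inhibition at the concentration tested (going by the name of the read-out), a lower number less inhibition), compound 1 `CN(C)c1ccc(C2CC(c3ccc(-n4ccnc4)cc3)=NN2)cc1` gives -20.9%.
In this assay compound 2 `COC(=O)CC(=O)N1N=C(c2ccc(N3CCN(C)CC3)cc2)CC1c1ccc(N(C)C)cc1` gives -8.3%.
In this assay compound 3 `COC(=O)CC(=O)N1N=C(c2ccc(-n3ccnc3)cc2)CC1c1ccc(N(C)C)cc1` gives 2.1%.

Compound 3 stands highest of the three values in this assay, although its own number is close to zero: it lies a number 10.4 percentage points higher from compound 2 to compound 3 (beyond the scatter) and a number 23 percentage points higher from compound 1 to compound 3 (beyond the scatter). Compound 4 `CN(C)c1ccc(C2CC(c3ccc(-n4ccnc4)cc3)=NN2S(=O)(=O)c2ccc(C#N)cc2)cc1` differs from compound 3 in one place: (4-cyanophenyl)sulfonyl in place of ((methoxycarbonyl)methyl)carbonyl on an amine nitrogen in a ring.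

Going by the values given here, only one measured step touches the same position. Going from compound 1, which carries a hydrogen on that ring nitrogen, to compound 3, which carries the ((methoxycarbonyl)methyl)carbonyl group there, gave a number 23 percentage points higher from compound 1 to compound 3 (beyond the scatter). Among the compounds with values here, that shows a substituent on this nitrogen can matter, but no measured pair compares two different substituents at the position, so the size of the exchange to (4-cyanophenyl)sulfonyl cannot be read from the data. The step of a number 5.9 percentage points higher from compound 3 to compound 4 (within the scatter) is therefore expected to be small, in the upward direction but possibly within the scatter. Compound 4 is estimated to give 8%, with a range from -15% to 35%.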

Compound 4, a percentage reported as inhibition, at one concentration (the size of the read-out at that concentration, not a potency): 4.7%
Compound 4: the middle estimate sits 3.3 percentage points above what was measured; low and high end bracket the measured number.
By their numbers in this assay, from the lowest: compound 1; then compound 2; then compounds 3 and 4 (each within the scatter of the next).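

The exchange on the amine nitrogen in the ring can now be read directly: in this assay it gives a number 2.6 percentage points higher from compound 3 to compound 4 (within the scatter), so ((methoxycarbonyl)methyl)carbonyl and the larger (4-cyanophenyl)sulfonyl, which brings a six-membered aromatic ring of carbon only, cannot be told apart here. Against hydrogen at the same position, the (4-cyanophenyl)sulfonyl group gives a number 25.6 percentage points higher from compound 1 to compound 4 (beyond the scatter), and this joins the earlier a number 23 percentage points higher from compound 1 to compound 3 (beyond the scatter), so both groups tried on this nitrogen stand beyond the scatter from the unsubstituted compound. That is a gain over a negative starting number and not strong inhibition, since compound 4 gives 4.7% at the single concentration tested.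

Nothing among the data shown explains why the numbers fall this way. From the compounds shown here alone, it also stays open whether a small acetyl group, a simple methyl, or a longer chain ending in a carboxylic acid or an amine on this nitrogen would behave like these two groups or would move the number well away from zero.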